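Benzyl for cyclohexylmethyl on a shared amide series

The compounds below may be only part of what the source reports. "The series", "measured", "known", "first", "only" and "open" are said of these compounds alone.

Measured compounds:
Compound 1, `CC(=O)c1cccc(N/C(=N/O)c2ccc3occc3c2)c1`: in an assay on isolated protein for inhibition of Indoleamine 2,3-dioxygenase 1 (Homo sapiens), read by spectrophotometry (a higher number here means a weaker inhibitor, a lower number a stronger inhibitor), compound 1 gives > 30000 nM, a limit of the assay.
Compound 2, `O=C(NCC1CCCCC1)c1cccc(N/C(=N/O)c2ccc3occc3c2)c1`: in this assay compound 2 gives > 30000 nM, a limit of the assay.

Compound 2 stands at a limit in this assay and at no number. Going by the values given here, the only measured step, a step that the two limits leave unreadable from compound 1 to compound 2, runs between two limits and its size cannot be read. The evidence is the limit of > 30000 nM in this assay, at which 2 of the 2 values shown sit; neither value places a compound inside the readable window.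

Compound 3, `O=C(NCc1ccccc1)c1cccc(N/C(=N/O)c2ccc3occc3c2)c1`, differs from compound 2 by phenyl in place of cyclohexyl on a saturated chain carbon bound to an amide-type nitrogen. Among the compounds with values here, no measured step bears on this change: the one step present concerns the carbonyl substituent and is itself unreadable, so it gives no direction and no size to carry over.

The expectation therefore rests on the two limits alone. Compound 3 is expected to sit near the same limit, and the step that the limit leaves unreadable from compound 2 to compound 3 is expected to be no readable step beyond the scatter. Compound 3 is estimated at 40000 nM, with a range from 10000 nM to 200000 nM, and most likely the assay again reports only a limit.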

Compound 3, half-maximal inhibitory concentration: > 30000 nM
Compound 3 gave a limit, no number (the forecaster's own chance of this, stated with the estimate: 80%); the middle value does not contradict the limit.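

No new step can be read, since compound 1, compound 2 and compound 3 all stand at a limit in this assay and the steps among them stay unreadable: the limit of > 30000 nM in this assay, at which 3 of the 3 values shown sit.

The compounds shown leave open whether any change on the shared core brings a value inside the readable window, and in which direction cyclohexyl and phenyl differ.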